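The source may report more compounds than this note shows. Statements on the series, on what has been measured and on what is new or still open speak of the compounds shown alone.

Compound 1 `O=C(Nc1ccc(Cl)cc1)c1c(NO)cc(-c2ccccc2)oc1=O` in an ADME assay on Huh-7 cells (Homo sapiens) for cytotoxicity, read by a luciferase reporter and WST assay, with a stated time of 3 days (on this read-out lower numbers stand for higher toxicity in this test and higher numbers for lower toxicity in this test), gives > 20000 nM, which is a limit of the assay rather than a number. Compound 2 `Cc1ccccc1NC(=O)c1c(NO)cc(-c2ccccc2)oc1=O` in this assay gives > 20000 nM, again a limit of the assay.

For the measured compounds named here, compound 2 therefore stands at the limit, as does the only other measured compound (the limit of > 20000 nM in this assay, at which 2 of the 2 values shown sit). Going by the values given here, the one step among measured compounds, a step that the two limits leave unreadable from compound 1 to compound 2, cannot be read because both of its ends are limits. Compound 3 `CNC(=O)c1c(NO)cc(-c2ccccc2)oc1=O` differs from compound 2 by methyl in place of 2-methylphenyl on an amide-type nitrogen. Among the compounds with values here, no measured step bears readably on this change, so nothing in the numbers points to a shift in either direction. Compound 3 is thus expected to sit where compound 2 sits, and the step that the limit leaves unreadable from compound 2 to compound 3 is estimated as none beyond the scatter. Compound 3 is estimated at 30000 nM in this assay, within a range of 12000 nM to 80000 nM, most likely reported again as a limit.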

Compound 3, half-maximal cytotoxic concentration: > 20000 nM
Compound 3: a limit, no number; the forecaster's own chance of this, stated with the estimate: 80%; the middle value does not contradict the limit.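

No step among compound 1, compound 2 and compound 3 can be read in this assay, because all of them stand at a limit of the assay: the limit of > 20000 nM in this assay, at which 3 of the 3 values shown sit.

The compounds shown leave open whether any change on the amide-type nitrogen shifts this read-out at all.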